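A few compounds are considered here, and "the series" means these few. Any claim that something is new, unique, unknown or untested is made for them only; others in the source may bear on it.

Of the compounds shown here, two sharing one core have been measured in an assay on isolated protein for binding affinity to 5-hydroxytryptamine receptor 1D (Homo sapiens); a lower number here means a stronger inhibitor, a higher number a weaker inhibitor. Compound 1 `Cc1cccc(-c2n[nH]cc2N2CCCNCC2)c1` gives 3290 nM in this assay. Compound 2 `Cc1ccc(-c2n[nH]cc2N2CCCNCC2)cc1` gives 892 nM in this assay, the lower of the two numbers, and its gap to compound 1 lies beyond the scatter. Compound 3 `Clc1ccc(-c2n[nH]cc2N2CCCNCC2)cc1` has not yet been measured. It differs from compound 2 by chloro in place of methyl on an aromatic carbon. Among the measured compounds shown here, no measured pair shows this change. The step of a 1.5-fold lower number from compound 2 to compound 3 (0.17 log units; within the scatter) is expected to be a small gain, within the scatter. Compound 3 is therefore estimated at 600 nM in this assay, between 200 nM and 1800 nM.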

Compound 3, inhibition constant: 1230 nM
Estimate against measurement, compound 3: 2.1-fold (0.31 log units) below; the range from low to high includes it.
By their numbers in this assay, from the lowest: compounds 2 and 3 (each within the scatter of the next); then compound 1.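

In this assay chloro in place of methyl on an aromatic carbon, para to a large group, gives a 1.4-fold higher number from compound 2 to compound 3 (0.14 log units; within the scatter) and so leaves the number within the scatter. At this position, the two groups therefore cannot be told apart, although this rests on one pair alone. No measurement at hand bears on why they match here. The compounds shown leave open whether a methoxy group, an amine or a carboxylic acid at this place would also stay within the scatter of compound 2.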